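The source may hold more compounds than are shown below. What is called first, only, known or untested is meant among the compounds shown, and "the series" means these compounds.

Measured compounds:
compound 1, `O=c1ccc(CCOCc2ccccc2)nn1Cc1ccccc1`: 32300 nM
compound 2, `Cn1nc(CCOCc2ccccc2)ccc1=O`: > 100000 nM
compound 3, `Cn1nc(CCO[Si](c2ccccc2)(c2ccccc2)C(C)(C)C)ccc1=O`: 47000 nM

Three compounds were tested in a functional assay on aorta (Rattus norvegicus); a lower number here means a stronger inhibitor, a higher number a weaker inhibitor. Compound 2 gives only a limit of the assay, > 100000 nM, and not a number. Compound 1 gives 32300 nM in this assay, and compound 3 gives 47000 nM; compound 3 stands highest of the two numbers, but its distance to compound 1 lies within the scatter, so no order between them is claimed.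

The pair compound 2 and compound 1 differ in one place, (phenyl in place of hydrogen on a saturated chain carbon bound to an aromatic nitrogen). That change brought an at least 3.0-fold lower number from compound 2 to compound 1 (0.49 log units; beyond the scatter). The size of that step is known only as a bound, since compound 2 sits at the limit of > 100000 nM in this assay, at which 1 of the 3 values shown sits.

The unmeasured compound 4, `CC(C)(C)[Si](OCCc1ccc(=O)n(Cc2ccccc2)n1)(c1ccccc1)c1ccccc1`, is derived from compound 3 by the same change, (phenyl in place of hydrogen on a saturated chain carbon bound to an aromatic nitrogen). The cores of compound 3 and compound 2 differ as well, but the difference between the two cores is not broken down here.

If the change behaves on the core of compound 3 as it did on the core of compound 2, compound 4 is expected to give a lower number than compound 3, an expected step of a 3.9-fold lower number from compound 3 to compound 4 (0.59 log units; beyond the scatter), resting on the step of an at least 3.0-fold lower number from compound 2 to compound 1 (0.49 log units; beyond the scatter) and the value of compound 3, 47000 nM. Compound 4 is therefore estimated at 12000 nM in this assay, with a range from 3000 nM to 40000 nM.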

Compound 4, half-maximal inhibitory concentration: > 100000 nM
Compound 4 ended at the assay's limit (the forecaster's own chance of this, stated with the estimate: 5%); middle value at least 8.3-fold (0.92 log units) from the limit.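

In this assay compound 4 sits at a limit of the assay, > 100000 nM, and not at a number. The step therefore reads an at least 2.1-fold higher number from compound 3 to compound 4 (0.32 log units; beyond the scatter), so methyl to benzyl did not carry over from the core of compound 2 to the core of compound 3, and the two steps run in opposite directions: the same change on two cores in this assay, an at least 3.0-fold lower number (0.49 log units; beyond the scatter) from compound 2 to compound 1 and an at least 2.1-fold higher number (0.32 log units; beyond the scatter) from compound 3 to compound 4, at least 6.5-fold (0.81 log units) apart, beyond the scatter of two such steps This shows that, in this series, the result of the change depends on the core it is made on, but it does not give the true size of either step, and with a single pair on each core it does not show which part of the cores matters, as both steps are known only as bounds: the limit of > 100000 nM in this assay, at which 2 of the 4 values shown sit.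

Going by these compounds, it remains open how the change would behave on further cores, since only these two pairs can be compared here. On these data alone, it also remains open whether another group at the same place, such as an amine, a carboxylic acid or a longer chain in place of the phenyl, would follow the pattern of compound 1 or that of compound 4 on either core.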